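Moving the Triazole One Carbon Outward

The compounds below may be only part of what the source reports. "The series", "measured", "known", "first", "only" and "open" are said of these compounds alone.

Compound 1 `CC(C)C(c1nnc[nH]1)c1ccc(-c2ccc3cccc(F)c3c2)[nH]c1=O` is the strongest of the three measured compounds in a functional assay on CHO cells for antagonist activity at prostaglandin E2 receptor EP3 subtype (Homo sapiens), read by cAMP accumulation (a higher number here means a weaker inhibitor, a lower number a stronger inhibitor), giving 21 nM. Its two neighbours share the same core and differ from it only in the group on the saturated chain carbon bound to an aromatic carbon and a saturated chain carbon: compound 2 `CC(C)C(CC(N)=O)c1ccc(-c2ccc3cccc(F)c3c2)[nH]c1=O` gives 53 nM, and compound 3 `CC(C)C(c1ccc(-c2ccc3cccc(F)c3c2)[nH]c1=O)N1CCCCS1(=O)=O` gives 122 nM. Both changes weakened inhibition, as a 2.5-fold higher number from compound 1 to compound 2 (0.40 log units; beyond the scatter) and a 5.8-fold higher number from compound 1 to compound 3 (0.76 log units; beyond the scatter) show.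

Compound 4 `CC(C)C(Cc1nnc[nH]1)c1ccc(-c2ccc3cccc(F)c3c2)[nH]c1=O` keeps the five-membered aromatic ring with 3 hetero atoms but places it one carbon further out: (4H-1,2,4-triazol-3-yl)methyl in place of 4H-1,2,4-triazol-3-yl on a saturated chain carbon bound to an aromatic carbon and a saturated chain carbon. Among the compounds with values here, no measured step is of exactly this kind, since compound 2 and compound 3 replace the ring rather than lengthen its tether; they show only that every departure from compound 1 at this position has so far cost potency by a modest amount. A similar modest loss is therefore expected, a 2.1-fold higher number from compound 1 to compound 4 (0.33 log units; beyond the scatter). Compound 4 is estimated at 45 nM, within a range from 15 nM to 140 nM.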

Compound 4, half-maximal inhibitory concentration: 17 nM
For compound 4 the middle estimate is 2.6-fold (0.42 log units) above the measured one; low and high end bracket the measured number.
By their numbers in this assay, from the lowest: compounds 4 and 1 (each within the scatter of the next); then compound 2; then compound 3.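

Replacing 4H-1,2,4-triazol-3-yl with (4H-1,2,4-triazol-3-yl)methyl leaves inhibition indistinguishable, with a 1.2-fold lower number from compound 1 to compound 4 (0.09 log units; within the scatter), so this position tolerates a lengthened tether as long as the ring is kept. The ring therefore matters more here than its exact distance from the core: with the same tether, carbamoyl in compound 2 gives way to the triazole in compound 4 with a 3.1-fold lower number from compound 2 to compound 4 (0.49 log units; beyond the scatter). The larger sulfur-containing ring of compound 3 stands further off, at a 7.2-fold lower number from compound 3 to compound 4 (0.86 log units; beyond the scatter), so both triazole compounds lie below both compounds without that ring.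

Nothing available explains why the triazole is preferred at this position. As far as these compounds go, it also remains open whether a longer chain carrying the same ring would hold this potency, or whether a carboxylic acid on the same tether would match it.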